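A Hydroxyethyl Chain in Place of the Dioxolane

A few compounds are considered here, and "the series" means these few. Any claim that something is new, unique, unknown or untested is made for them only; others in the source may bear on it.

Compound 1 (`Cc1cccc(-c2cn(C[C@H]3COC(C)(C)O3)nn2)c1`): > 100000 nM, a limit of the assay.
Compound 2 (`CC1(C)OCC(Cn2cc(-c3ccc(C(F)(F)F)cc3)nn2)O1`): 13500 nM.
Compound 3 (`CC1(C)OCC(Cn2cc(-c3ccc([N+](=O)[O-])cc3)nn2)O1`): > 100000 nM, a limit of the assay.

Among the measured compounds shown here, in a functional assay on B16 cells (Mus musculus) for cytotoxicity, read by MTT assay, with a stated time of 48 h (on this read-out higher numbers stand for weaker inhibition and lower numbers for stronger inhibition), compound 2 gives 13500 nM, the only number among the three measured compounds; the other two sit at the limit of > 100000 nM in this assay, at which 2 of the 3 values shown sit. For the measured compounds named here, the single measured step alters the group on the aromatic ring: an at least 7.4-fold higher number from compound 2 to compound 3 (0.86 log units; beyond the scatter). Compound 4 (`OCCCn1cc(-c2ccc(C(F)(F)F)cc2)nn1`) departs from compound 2 at a different site: 2-hydroxyethyl in place of 2,2-dimethyl-1,3-dioxolan-4-yl on a saturated chain carbon bound to an aromatic nitrogen. Going by the values given here, no measured step touches this chain-bound position, and the step at the aromatic ring does not bear on it. The step expected in this assay is therefore a 1.5-fold higher number from compound 2 to compound 4 (0.17 log units; within the scatter), within the scatter. Compound 4 is estimated at 20000 nM, with a range from 6000 nM to 100000 nM.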

Compound 4, half-maximal inhibitory concentration: > 100000 nM
Compound 4 ended at the assay's limit (the forecaster's own chance of this, stated with the estimate: 30%); middle value at least 5.0-fold (0.69 log units) from the limit.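

In this assay, 2-hydroxyethyl in place of 2,2-dimethyl-1,3-dioxolan-4-yl on a saturated chain carbon bound to an aromatic nitrogen gives an at least 7.4-fold higher number from compound 2 to compound 4 (0.86 log units; beyond the scatter). The chain-bound position therefore matters too, since this change, with trifluoromethyl kept on the aromatic ring, is enough to lose the measurable number of compound 2. Compound 4 stands at a limit of the assay, so this step is a bound and not a size: the limit of > 100000 nM in this assay, at which 3 of the 4 values shown sit.

Going by these compounds, it remains open how far the change can be reversed at this position. A 2,3-dihydroxypropyl group, an amine or a longer chain might or might not return a measurable number.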